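The source may report more compounds than this note shows. Statements on the series, on what has been measured and on what is new or still open speak of the compounds shown alone.

In a functional assay on the whole organism (blood) with Rattus norvegicus as the target, with stated times of 24 h and 1 h, at a dose of 15 mg/kg by the intraperitoneal route (on this read-out higher numbers stand for a stronger effect at the one dose given and lower numbers for a weaker effect), three compounds have been measured:

- compound 1, `O=C(NC[C@@H]1C[C@@H]2C=C[C@@H]1C2)NS(=O)(=O)N1CCC(CCNC(=O)c2cnsc2)CC1`, gives 14%
- compound 2, `O=C(NC[C@@H]1C[C@@H]2C=C[C@@H]1C2)NS(=O)(=O)N1CCC(CCNC(=O)c2cc(Cl)ccn2)CC1`, gives 46%
- compound 3, `O=C(NC[C@@H]1C[C@@H]2C=C[C@@H]1C2)NS(=O)(=O)N1CCC(CCNC(=O)c2cnccc2Cl)CC1`, gives 12%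

Compound 3 stands at the bottom of these three numbers. Its gap to compound 1 is small, a number 2 percentage points lower from compound 1 to compound 3 (within the scatter), and so the two cannot be told apart. Against compound 2 the distance is clear, a number 34 percentage points lower from compound 2 to compound 3 (beyond the scatter), and in the same way compound 1 lies far under compound 2, a number 32 percentage points higher from compound 1 to compound 2 (beyond the scatter). All three differ only in the aromatic ring attached to the carbonyl carbon, so this one place already moves this assay from nothing beyond the scatter to a large step.

Compound 4, `Cn1cccc(C(=O)NCCC2CCN(S(=O)(=O)NC(=O)NC[C@@H]3C[C@@H]4C=C[C@@H]3C4)CC2)c1=O`, changes the same place again: a group of 8 heavy atoms (6 carbon, 1 nitrogen, 1 oxygen; one six-membered aromatic ring with 1 hetero atom) in place of a group of 7 heavy atoms (5 carbon, 1 nitrogen, 1 chlorine; one six-membered aromatic ring with 1 hetero atom), on a carbonyl carbon. Among the measured compounds shown here, the entering ring appears in no measured compound, so the three steps above give only the range of what a ring swap here has done, not its direction for this case. Two of the three swaps gave large steps, one gave none. An upward move is therefore possible, a flat result equally so. Weighing both, compound 4 is expected to give about 20%, between 5% and 45%, which would mean an estimated step of a number 8 percentage points higher from compound 3 to compound 4 (within the scatter).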

Compound 4, a percentage reported as activity, at one dose (the size of the read-out at that dose, not a potency): 40%
The estimate for compound 4 lay 20 percentage points below the measured number; the measured number falls inside the stated range.
By their numbers in this assay, from the lowest: compounds 3 and 1 (each within the scatter of the next); then compounds 4 and 2 (each within the scatter of the next).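

Swapping in the new ring on the carbonyl carbon moves this assay up by a clear margin in two comparisons (a number 28 percentage points higher from compound 3 to compound 4 (beyond the scatter)) (a number 26 percentage points higher from compound 1 to compound 4 (beyond the scatter)), while the third comparison shows no separation (a number 6 percentage points lower from compound 2 to compound 4 (within the scatter)). The four compounds therefore fall into a low pair and a high pair, and neither the chlorine nor the ring type sorts them: compound 4 has no chlorine yet cannot be told apart from chlorine-bearing compound 2, whereas chlorine-bearing compound 3 cannot be told apart from chlorine-free compound 1, and compound 3 and compound 4 both carry a six-membered aromatic ring with 1 hetero atom yet lie far apart. Nothing available explains why these rings divide as they do.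

On these data alone, it remains open whether a plain phenyl ring or a saturated piperidine ring on the same carbonyl carbon would join the high pair or the low pair. Since each compound was read at a single dose, the data also cannot say whether compound 2 and compound 4 match in potency.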